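Nitro placement on the aryl hydrazone of the terpenoid thiosemicarbazide

The source may hold more compounds than are shown below. What is called first, only, known or untested is meant among the compounds shown, and "the series" means these compounds.

Compound 1 `CC1=CC[C@@H]([C@@](C)(O)CCCC(C)(C)NC(=S)N/N=C\c2ccccc2)CC1` is the unsubstituted phenyl member of the series. For the measured compounds named here, in a functional assay on K562 cells (Homo sapiens) for cytotoxicity, read by sulforhodamine B assay (a lower number here means a stronger inhibitor of growth, a higher number a weaker inhibitor of growth), compound 1 gives 20900 nM, the highest of the three numbers measured so far. Compound 2 `CC1=CC[C@@H]([C@@](C)(O)CCCC(C)(C)NC(=S)N/N=C\c2ccc(C)cc2)CC1` carries a methyl on the ring and gives 7950 nM; compound 3 `CC1=CC[C@@H]([C@@](C)(O)CCCC(C)(C)NC(=S)N/N=C\c2ccccc2[N+](=O)[O-])CC1` carries a nitro group and gives 7840 nM. The two substituted analogues sit close together: a 1.0-fold lower number from compound 2 to compound 3 (0.01 log units; within the scatter). Both steps away from compound 1 are modest but real, a 2.6-fold lower number from compound 1 to compound 2 (0.42 log units; beyond the scatter) and a 2.7-fold lower number from compound 1 to compound 3 (0.43 log units; beyond the scatter).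

Compound 4 `CC1=CC[C@@H]([C@@](C)(O)CCCC(C)(C)NC(=S)N/N=C\c2cccc([N+](=O)[O-])c2)CC1` differs from compound 1 by nitro in place of hydrogen on an aromatic carbon. Going by the values given here, the step from compound 1 to compound 3 is the closest precedent, introducing the same nitro group on another aromatic carbon of the same ring, and the step to compound 2 shows that a second, unrelated ring substituent moves the number by about the same amount. A modest lowering is therefore expected for compound 4, of the order of a 2.7-fold lower number from compound 1 to compound 4 (0.43 log units; beyond the scatter). On that basis compound 4 is estimated at 7800 nM, with a likely range from 3500 nM to 17000 nM.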

Compound 4, concentration for total growth inhibition: 560 nM
The estimate for compound 4 lay 14-fold (1.14 log units) above the measured number, and the stated range ends above it.
By their numbers in this assay, from the lowest: compound 4; then compounds 3 and 2 (each within the scatter of the next); then compound 1.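

In this assay, for the compounds shown here, the position of the nitro group matters far more than compounds 1 to 3 indicated: the two nitro isomers are separated, with a 14-fold lower number from compound 3 to compound 4 (1.15 log units; beyond the scatter), and the gain over the unsubstituted phenyl, a 37-fold lower number from compound 1 to compound 4 (1.57 log units; beyond the scatter), is large where the earlier steps from compound 1 were modest. Ring substitution alone does not account for this gain, since the 3-nitrophenyl group also stands apart from the 4-methylphenyl group, with a 14-fold lower number from compound 2 to compound 4 (1.15 log units; beyond the scatter). Nothing available here explains why this position behaves so differently.

As far as these compounds go, whether the gain belongs to the nitro group itself or to any substituent on this aromatic carbon remains open, as a nitrile, an amine or a carboxylic acid there would test. Also open, from the compounds shown here alone, is whether the gain carries over to a core with a shorter chain.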